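Chloro for Amine Swap on Two Ether Cores

This account rests on a few compounds, and the source may have more. Where it says the series, first, only, none or still open, it means among the compounds named here.

Compound 1 `CN(C)CCCNc1ccnc2cc(OCc3ccc(F)cc3)ccc12` gives 740 nM in a functional assay on HCT-116 cells (Homo sapiens) for cytotoxicity, read by MTT assay, with a stated time of 48 h; on this read-out lower numbers stand for stronger inhibition and higher numbers for weaker inhibition. Compound 2 `Fc1ccc(COc2ccc3c(Cl)ccnc3c2)cc1` carries chloro in place of (3-(dimethylamino)propyl)amino on an aromatic carbon; in this assay compound 2 gives 2070 nM, which amounts to a 2.8-fold higher number from compound 1 to compound 2 (0.45 log units; beyond the scatter). Compound 3 `C=CCOc1ccc2c(NCCCN(C)C)ccnc2c1` differs from compound 1 in the core by vinyl in place of 4-fluorophenyl on a saturated chain carbon bound to an oxygen on an aromatic ring; in this assay compound 3 gives 2100 nM, which amounts to a 2.8-fold higher number from compound 1 to compound 3 (0.45 log units; beyond the scatter). The values of compound 2 and compound 3 lie within the usual scatter of each other.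

Compound 4 `C=CCOc1ccc2c(Cl)ccnc2c1` has not been measured. It is built from compound 3 by chloro in place of (3-(dimethylamino)propyl)amino on an aromatic carbon, the same change that turns compound 1 into compound 2, at a place described in identical words for both pairs; the two cores differ as noted for compound 3 against compound 1. Among the measured compounds shown here, only one earlier instance of this change exists, so the expectation rests on that step alone, a 2.8-fold higher number from compound 1 to compound 2 (0.45 log units; beyond the scatter). Compound 4 is therefore expected to show a 2.8-fold higher number from compound 3 to compound 4 (0.45 log units; beyond the scatter) in this assay. Compound 4 is estimated at 5900 nM, with a likely range from 2500 nM to 14000 nM.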

Compound 4, half-maximal inhibitory concentration: 2570 nM
Beside the measured number, compound 4's estimate is 2.3-fold (0.36 log units) above it; low and high end bracket the measured number.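

In this assay, chloro in place of (3-(dimethylamino)propyl)amino on the core of compound 3 gives a 1.2-fold higher number from compound 3 to compound 4 (0.09 log units; within the scatter), a step that cannot be told from the scatter. Set beside the earlier instance on the core of compound 1, the change carries over with no difference that can be separated from the scatter: the same change on two cores in this assay, a 2.8-fold higher number (0.45 log units; beyond the scatter) from compound 1 to compound 2 and a 1.2-fold higher number (0.09 log units; within the scatter) from compound 3 to compound 4, 2.3-fold (0.36 log units) apart, within the scatter of two such steps. Among the compounds shown here, this supports reading the two steps as compatible, but with only two pairs, one beyond the scatter and one within it, it establishes neither a common size for the step nor a reliable direction on every core.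

The compounds shown leave open how a longer aminoalkyl chain or a piperazine at this place would compare with chloro on these two cores. Also open, going by these compounds, is whether the step holds on a core with a different group on the ether oxygen, such as a plain alkyl chain or a chain ending in a carboxylic acid.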